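Primary amide in place of morpholine on the arylidene cyanoacetamide core

A few compounds are considered here, and "the series" means these few. Any claim that something is new, unique, unknown or untested is made for them only; others in the source may bear on it.

Three measured compounds share one core. Compound 1 `N#C/C(=C\c1cc(O)c(O)c([N+](=O)[O-])c1)C(=O)Nc1ccccc1Cl`, the anilide, gives 37.4 ug/mL in a functional assay on KB cells (Homo sapiens) for antiproliferative activity, read by MTT assay; a higher number here means a weaker inhibitor, a lower number a stronger inhibitor. Compound 2 `N#C/C(=C\c1cc(O)c(O)c([N+](=O)[O-])c1)C(=O)N1CCCCC1` gives > 100 ug/mL in this assay, which is a limit of the assay. Compound 3 `N#C/C(=C\c1cc(O)c(O)c([N+](=O)[O-])c1)C(=O)N1CCOCC1` gives > 100 ug/mL in this assay, again a limit. The change from the anilide to the piperidine amide gives an at least 2.6-fold higher number from compound 1 to compound 2 (0.42 log units; beyond the scatter), and the change to the morpholine amide gives an at least 2.6-fold higher number from compound 1 to compound 3 (0.42 log units; beyond the scatter). Between the two cyclic amides the step is a step that the two limits leave unreadable from compound 2 to compound 3, unreadable because the limit of > 100 ug/mL in this assay, at which 2 of the 3 values shown sit, leaves both ends open. Compound 3 therefore stands at the top of the numbers shown, with no finite value.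

Compound 4 `N#C/C(=C\c1cc(O)c(O)c([N+](=O)[O-])c1)C(N)=O` carries the change (amino in place of morpholin-4-yl on a carbonyl carbon). Going by the values given here, no measured step bears directly on a primary amide; the only related steps are those from compound 1 to the two cyclic amides, both of which moved the number past the limit. Compound 3 itself offers no finite anchor, so the expected step, an at least 1.1-fold lower number from compound 3 to compound 4 (0.04 log units; that floor lies within the scatter), rests on the anilide value as the lowest finite point and on the two limits as the likely neighbourhood. Compound 4 is expected to give about 90 ug/mL in this assay, with a range from 30 ug/mL to 300 ug/mL.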

Compound 4, half-maximal inhibitory concentration: > 100 ug/mL
Compound 4: a limit, no number; the forecaster's own chance of this, stated with the estimate: 55%; at least 1.1-fold (0.04 log units) between middle value and limit.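

In this assay compound 4 gives > 100 ug/mL, which is a limit of the assay. On the carbonyl carbon, the small amino group with no ring therefore ends at the same limit as the two cyclic amides, and hydrogen in place of 2-chlorophenyl on the amide-type nitrogen gives an at least 2.6-fold higher number from compound 1 to compound 4 (0.42 log units; beyond the scatter). Among the four compounds shown, a finite value thus appears only with the 2-chlorophenyl amide, while the steps among compound 2, compound 3 and compound 4 cannot be read: the limit of > 100 ug/mL in this assay, at which 3 of the 4 values shown sit.

On these data alone, whether the finite value of compound 1 depends on the chlorine or on the aromatic ring alone stays open, and an unsubstituted phenyl on the amide-type nitrogen would separate the two. A benzyl group or a methylamino group on the carbonyl carbon would also show whether anything other than a directly attached aryl group gives a finite value in this assay.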